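Swapping the five-membered ring heteroatom in a CXCR4 antagonist series

The source may hold more compounds than are shown below. What is called first, only, known or untested is meant among the compounds shown, and "the series" means these compounds.

Of the compounds shown here, three sharing one core have been measured in a functional assay on CEM-CCRF cells for antagonist activity at C-X-C chemokine receptor type 4 (Homo sapiens), read by calcium flux; on this read-out lower numbers stand for stronger inhibition and higher numbers for weaker inhibition. Compound 1 `NCc1cc(CO)ccc1CN(Cc1nc2ccccc2[nH]1)C1CCCc2cccnc21` gives 11 nM in this assay, compound 2 `NCc1cc(C(=O)O)ccc1CN(Cc1nc2ccccc2[nH]1)C1CCCc2cccnc21` gives 126 nM, and compound 3 `NCc1sccc1CN(Cc1nc2ccccc2[nH]1)C1CCCc2cccnc21` gives 60 nM. Compound 3 therefore holds the second highest number of the three: a 5.5-fold higher number from compound 1 to compound 3 (0.74 log units; beyond the scatter) separates it from compound 1, while a 2.1-fold lower number from compound 2 to compound 3 (0.32 log units; beyond the scatter) separates it from compound 2.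

Compound 4 `NCc1occc1CN(Cc1nc2ccccc2[nH]1)C1CCCc2cccnc21` differs from compound 3 in one place: a group of 7 heavy atoms (5 carbon, 1 nitrogen, 1 oxygen; one five-membered aromatic ring with 1 hetero atom) in place of a group of 7 heavy atoms (5 carbon, 1 nitrogen, 1 sulfur; one five-membered aromatic ring with 1 hetero atom), on a saturated chain carbon bound to an amine nitrogen. Among the compounds with values here, none of the measured steps exchanges only the hetero atom of this five-membered ring. The steps that touch the same position, the move from compound 1 to compound 3 and the move from compound 2 to compound 3, each replace a six-membered ring with a substituent by the ring bearing sulfur, and both are modest in size, whereas an 11-fold higher number from compound 1 to compound 2 (1.06 log units; beyond the scatter) concerns a substituent change on the six-membered ring and is large. Because compound 3 gives 60 nM with the ring bearing sulfur in this place, and the ring bearing oxygen differs from it in nothing but the hetero atom, the expected step of a 1.3-fold higher number from compound 3 to compound 4 (0.12 log units; within the scatter) is small and may not rise beyond the scatter. Compound 4 is thus estimated at 80 nM in this assay, with a range from 30 nM to 250 nM.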

Compound 4, half-maximal inhibitory concentration: 21 nM
Estimate against measurement, compound 4: 3.8-fold (0.58 log units) above, outside the stated range (below it).
By their numbers in this assay, from the lowest: compounds 1 and 4 (each within the scatter of the next); then compound 3; then compound 2.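

In this assay, the hetero atom of the five-membered aromatic ring on a saturated chain carbon bound to an amine nitrogen proves to matter by itself, since oxygen in place of sulfur, with everything else kept, gives a 2.9-fold lower number from compound 3 to compound 4 (0.46 log units; beyond the scatter). The five-membered ring as such therefore does not set the distance from the six-membered ring of carbon only: the ring bearing sulfur stood apart from compound 1 beyond the scatter, whereas the ring bearing oxygen gives a 1.9-fold higher number from compound 1 to compound 4 (0.28 log units; within the scatter) and so cannot be told from compound 1 in this read-out. The distance from the carboxy compound also grows with this hetero atom, to a 6.0-fold lower number from compound 2 to compound 4 (0.78 log units; beyond the scatter) against a 2.1-fold lower number from compound 2 to compound 3 (0.32 log units; beyond the scatter) for the ring bearing sulfur.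

No measurement is at hand that would explain why the two hetero atoms part in this way. The compounds shown leave open how a five-membered aromatic ring with nitrogen as its hetero atom would read at this place, and whether a hydroxymethyl or a carboxylic acid group, which separates two compounds on the six-membered ring, would have a similar effect on the ring bearing oxygen.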